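The source may hold more compounds than are shown below. What is called first, only, known or untested is meant among the compounds shown, and "the series" means these compounds.

Compound 1 `Fc1cccc(-c2nc(Nc3ccccc3F)c3cc(F)ccc3n2)c1` gives > 50000 nM
Compound 2 `Fc1cccc(-c2nc(Nc3cccc(Br)c3)c3cc(F)ccc3n2)c1` gives > 50000 nM
Compound 3 `Oc1cccc(Nc2nc(-c3cccc(F)c3)nc3ccc(F)cc23)c1` gives > 50000 nM

These readings come from a functional assay on U-937 cells (Homo sapiens) for cytotoxicity, read by MTT assay, with a stated time of 48 h (a lower number here means a stronger inhibitor, a higher number a weaker inhibitor), and each one is a limit of the assay, not a number. Compound 3 gives > 50000 nM, which is a limit. It therefore has no exact place in the series, and it shares its position with the other two compounds: the limit of > 50000 nM in this assay, at which 3 of the 3 values shown sit.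

The next compound, compound 4 `Cc1ccccc1Nc1nc(-c2cccc(F)c2)nc2ccc(F)cc12`, carries 2-methylphenyl in place of 3-hydroxyphenyl on a nitrogen on an aromatic ring.

For the measured compounds named here, three measured steps bear on this change, all of them altering the group on that nitrogen: a step that the two limits leave unreadable from compound 1 to compound 2, a step that the two limits leave unreadable from compound 1 to compound 3 and a step that the two limits leave unreadable from compound 2 to compound 3. None has a readable size, so they offer no direction and no measure for a further swap. Going by the values given here, the only guide is that the 2-fluorophenyl, 3-bromophenyl and 3-hydroxyphenyl compounds all end at the same limit, as the limit of > 50000 nM in this assay, at which 3 of the 3 values shown sit, shows.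

The expected change, a number no higher from compound 3 to compound 4 (the limit leaves the size open), is therefore estimated to be none beyond the scatter, with no direction favoured. The reading for compound 4 will most likely be a limit again. As a number, the estimate for compound 4 is 50000 nM, with an expected range from 20000 nM to 100000 nM.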

Compound 4, half-maximal inhibitory concentration: > 50000 nM
Compound 4: a limit, no number; the forecaster's own chance of this, stated with the estimate: 80%; the middle value lies on the limit itself.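

In this assay compound 4 gives > 50000 nM, which is a limit of the assay and not a number. The steps linking compound 4 to compound 1, compound 2 and compound 3 cannot be read, and all four compounds share one position: the limit of > 50000 nM in this assay, at which 4 of the 4 values shown sit. The compounds shown leave open which group on that nitrogen, if any, would give a measurable value.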